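The compounds below may be only part of what the source reports. "The series", "measured", "known", "first", "only" and "open" are said of these compounds alone.

Working notes on the series. Compound 2, `COC(=O)c1cc(-c2cccc(NC(=O)c3ccc(/C=C/C(=O)c4ccc(Br)cc4)cc3)c2)on1`, stands in an ADME assay on Vero cells (Chlorocebus sabaeus) for cytotoxicity, read by MTT assay, with a stated time of 72 h (on this read-out lower numbers stand for higher toxicity in this test and higher numbers for lower toxicity in this test), at > 20 ug/mL, which is a limit of the test rather than a number. Compound 1, `COC(=O)c1cc(-c2cccc(NC(=O)c3ccc(/C=C/C(=O)c4cccc(F)c4)cc3)c2)on1`, also returns only a limit there, > 40 ug/mL. Going by the values given here, the one measured step, a step that the two limits leave unreadable from compound 1 to compound 2, changes the same place as the step at hand but stays unreadable because the limit of > 20 ug/mL in this assay, at which 1 of the 2 values shown sits, and the limit of > 40 ug/mL in this assay, at which 1 of the 2 values shown sits, both cap the values. Compound 3, `COC(=O)c1cc(-c2cccc(NC(=O)c3ccc(/C=C/C(=O)c4ccc(OC)c([N+](=O)[O-])c4)cc3)c2)on1`, differs from compound 2 by 4-methoxy-3-nitrophenyl in place of 4-bromophenyl on a carbonyl carbon. With no readable step to lean on, no step beyond the scatter is expected in this assay. Compound 3 is estimated at 40 ug/mL, between 15 ug/mL and 80 ug/mL, a step that the limit leaves unreadable from compound 2 to compound 3.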

Compound 3, half-maximal cytotoxic concentration: > 40 ug/mL
Compound 3: no number, only a limit; the forecaster's own chance of this, stated with the estimate: 65%; the middle value lies on the limit itself.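

In this assay, going by these compounds alone, compound 1, compound 2 and compound 3 each return only a limit, so no step among them can be read. The compounds shown leave open whether 3-fluorophenyl, 4-bromophenyl and 4-methoxy-3-nitrophenyl on a carbonyl carbon differ at all in this test.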